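Chain extension on the amino substituent of compound 2

A few compounds are considered here, and "the series" means these few. Any claim that something is new, unique, unknown or untested is made for them only; others in the source may bear on it.

Compound 1, `c1ccc(Cn2nnc3c(NC4CCC4)nc(-c4ccccc4)nc32)cc1`: 5 nM
Compound 2, `OCCNc1nc(-c2ccccc2)nc2c1nnn2Cc1ccccc1`: 38 nM

Of the compounds shown here, two have been measured in an assay on Cerebral cortex for displacement of a labelled ligand from adenosine receptor A1 (Bos taurus); on this read-out lower numbers stand for stronger inhibition and higher numbers for weaker inhibition. Compound 1 gives 5 nM, and compound 2 gives 38 nM, the highest of the two numbers. Going by the values given here, the one measured step is a 7.6-fold higher number from compound 1 to compound 2 (0.88 log units; beyond the scatter), which replaces cyclobutyl with 2-hydroxyethyl on a nitrogen on an aromatic ring.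

Compound 3, `OCCCNc1nc(-c2ccccc2)nc2c1nnn2Cc1ccccc1`, has not yet been measured in this assay. It differs from compound 2 by hydroxymethyl in place of hydroxy on a saturated chain carbon, two bonds along the chain from a nitrogen on an aromatic ring. Read one bond further out, this is 2-hydroxyethyl to 3-hydroxypropyl, or (2-hydroxyethyl)amino to (3-hydroxypropyl)amino.

Among the compounds with values here, no measured step bears on this change. Within the data shown here, the only step, from compound 1 to compound 2, swaps a ring for a chain and does not speak to lengthening a chain by one carbon. With nothing to lean on, a change no larger than the scatter is expected, with the direction left open. The estimated step is a 1.3-fold lower number from compound 2 to compound 3 (0.10 log units; within the scatter). Compound 3 is therefore expected to give about 30 nM in this assay, with a range from 10 nM to 100 nM.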

Compound 3, inhibition constant: 21.4 nM
For compound 3 the middle estimate is 1.4-fold (0.15 log units) above the measured one; measured number inside the range.
By their numbers in this assay, from the lowest: compound 1; then compounds 3 and 2 (each within the scatter of the next).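

In this assay, moving from 2-hydroxyethyl to 3-hydroxypropyl on the nitrogen gives a 1.8-fold lower number from compound 2 to compound 3 (0.25 log units; within the scatter), so this read-out does not separate the two hydroxy chains and the added carbon leaves no change that can be told from the scatter. Going from cyclobutyl to 3-hydroxypropyl gives a 4.3-fold higher number from compound 1 to compound 3 (0.63 log units; beyond the scatter), so the gap between the ring and a hydroxy chain, first seen with 2-hydroxyethyl, stays beyond the scatter with the longer chain as well. No measurement at hand explains these numbers.

What the compounds shown leave open is whether a longer chain, such as 4-hydroxybutyl, would still give a number close to those of compound 2 and compound 3, or would depart from them. As far as these compounds go, it also remains open whether the hydroxy itself matters, since a plain propyl chain, a methoxy group or an amine at the end of the chain would be needed to show if the distance to compound 1 depends on that end group or on the ring of cyclobutyl.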